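This account rests on a few compounds, and the source may have more. Where it says the series, first, only, none or still open, it means among the compounds named here.

Measured compounds and their values:

Compound 1, `COc1cc(/C(Cl)=C/C=C(\C#N)C(=O)c2c[nH]c3ccccc23)cc(OC)c1OC`: 21.1%
Compound 2, `COc1ccc(/C(Cl)=C/C=C(\C#N)C(=O)c2c(C)[nH]c3ccccc23)cc1`: 34.2%
Compound 3, `COc1ccc2[nH]cc(C(=O)/C(C#N)=C/C=C(\Cl)c3ccc(OC)c(OC)c3)c2c1`: 34.2%

In a functional assay for inhibition, with a stated time of 30 min, tested at 1 mM (a lower number here means less inhibition, a higher number more inhibition at the concentration tested (going by the name of the read-out)), compound 3 gives 34.2%. At the digits printed this is level with compound 2, which gives 34.2%, and the two together are the highest of the three numbers; the two values lie within the scatter of each other, so no order between them can be read. Compound 1 stands furthest from compound 3, with a number lower by a margin that lies beyond the scatter.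

Going by the values given here, no pair of measured compounds differs in a single place, so no measured step is available to lean on. Compound 4, `COc1ccc2[nH]cc(C(=O)/C(C#N)=C/C=C(\Cl)c3ccc(Br)cc3)c2c1`, has not yet been measured. It differs from compound 3 in one place: 4-bromophenyl in place of 3,4-dimethoxyphenyl on a double-bonded chain carbon bound to a chlorine atom and a double-bonded chain carbon.

Without a measured step for a change of this kind, the expectation rests on the spread of the three numbers, which stay in a narrow band. The step from compound 3 to compound 4 is expected to be small and downward or none beyond the scatter, a number 6.2 percentage points lower from compound 3 to compound 4 (within the scatter). For compound 4 in this assay the estimated value is 28%, with a range from 10% to 45%.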

Compound 4, a percentage reported as inhibition, at one concentration (the size of the read-out at that concentration, not a potency): 40.8%
The estimate for compound 4 lay 12.8 percentage points below the measured number; the range from low to high includes it.
By their numbers in this assay, from the lowest: compound 1; then compounds 2, 3 and 4 (each within the scatter of the next).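

In this assay, putting 4-bromophenyl in place of 3,4-dimethoxyphenyl on a double-bonded chain carbon bound to a chlorine atom and a double-bonded chain carbon gives a number 6.6 percentage points higher from compound 3 to compound 4 (within the scatter). Going by these compounds alone, this is the first comparison in the set in which only one place differs, and it shows that this position can hold a group with fewer heavy atoms and no hydrogen-bond acceptors, and without either methoxy group, with no difference that can be told from the scatter. Nothing available bears on the reason for this result.

On these data alone, it remains open whether a group of a different kind at this place, such as a phenyl ring carrying an amine or a carboxylic acid, would leave the number in the same band, and whether a ring without any added group would do the same. As far as these compounds go, both numbers are also readings at a single concentration rather than potencies, so how compound 3 and compound 4 would compare across a range of concentrations stays unknown.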